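Dichlorobenzyl step in the benzyl series

The source may hold more compounds than are shown below. What is called first, only, known or untested is meant among the compounds shown, and "the series" means these compounds.

Measured so far in a functional assay on NCI-H460 cells (Homo sapiens) for cytotoxicity, read by MTT assay, with a stated time of 72 h (on this read-out higher numbers stand for weaker inhibition and lower numbers for stronger inhibition), compound by compound
- compound 1 `CCN(CC)Cc1ccc2nc(NC(=O)N/N=C/c3cn(Cc4ccc(Cl)cc4Cl)c4ccccc34)sc2c1` gives 1080 nM
- compound 2 `CCN(CC)Cc1ccc2nc(NC(=O)N/N=C/c3cn(Cc4ccc(Cl)cc4)c4ccccc34)sc2c1` gives 370 nM
- compound 3 `CCN(CC)Cc1ccc2nc(NC(=O)N/N=C/c3cn(Cc4ccccc4)c4ccccc34)sc2c1` gives 450 nM

Compound 3 (450 nM) lies within the scatter of compound 2 (370 nM), and both lie below compound 1 (1080 nM). Compound 4 `CCN(CC)Cc1ccc2nc(NC(=O)N/N=C/c3cn(Cc4ccc(Cl)c(Cl)c4)c4ccccc34)sc2c1` is still to be measured. Its difference from compound 3 is 3,4-dichlorophenyl in place of phenyl on a saturated chain carbon bound to an aromatic nitrogen, that is, benzyl to 3,4-dichlorobenzyl.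

Among the measured compounds shown here, no compound with this exact dichloro pattern has a value yet, so the nearest evidence comes from compound 1. Two steps show the loss of chloro from it: a 2.4-fold lower number from compound 1 to compound 3 (0.38 log units; beyond the scatter) and a 2.9-fold lower number from compound 1 to compound 2 (0.47 log units; beyond the scatter). For the measured compounds named here, by contrast, a 1.2-fold higher number from compound 2 to compound 3 (0.09 log units; within the scatter), so the single chloro of compound 2 does not separate it from compound 3. Going by the values given here, only the one dichloro compound supports a shift, and its chloro groups are placed differently from those of compound 4. A modest move toward a higher number is therefore expected, similar in size to the step from compound 1, with real uncertainty. The expected change is a 2.1-fold higher number from compound 3 to compound 4 (0.32 log units; beyond the scatter), and a result inside the scatter would not be surprising. For compound 4 the estimated value is 950 nM, with an expected range of 380 nM to 2000 nM, which closes these notes until the measurement arrives.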

Compound 4, half-maximal inhibitory concentration: 610 nM
Estimate against measurement, compound 4: 1.6-fold (0.19 log units) above; measured number inside the range.
By their numbers in this assay, from the lowest: compounds 2, 3, 4 and 1 (each within the scatter of the next, the first and the last beyond it).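

In this assay, the change from phenyl to 3,4-dichlorophenyl on a saturated chain carbon bound to an aromatic nitrogen gives a 1.4-fold higher number from compound 3 to compound 4 (0.13 log units; within the scatter) and the further chloro in place of hydrogen gives a 1.6-fold higher number from compound 2 to compound 4 (0.22 log units; within the scatter) so two chloro groups on this ring do not by themselves separate a compound from the unsubstituted or single-chloro benzyl compounds. Moving from the 2,4-dichlorophenyl to the 3,4-dichlorophenyl pattern gives a 1.8-fold lower number from compound 1 to compound 4 (0.25 log units; within the scatter) and this leaves compound 4 unresolved from every other compound in the set, while compound 1 at 1080 nM remains separated only from compound 2 and compound 3. Nothing beyond these cell read-outs is available to account for this pattern.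

The compounds shown leave open whether the separation of compound 1 belongs to the 2,4-dichlorophenyl pattern in particular, with a single dichloro pair on each side of the comparison and the step between them inside the scatter. Also open, on these data alone, is whether a group other than chloro on this ring, such as methoxy, an amine or a carboxylic acid, or a longer chain in place of the benzyl link, would move the number beyond the scatter from compound 3.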